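Adding a Second Chloro to an Amide That Shows No Activity

The source may report more compounds than this note shows. Statements on the series, on what has been measured and on what is new or still open speak of the compounds shown alone.

Compound 1, `O=C(Nc1ccc(Cl)c(-c2nnc3c(Cl)cccn23)c1)c1ccc(F)cc1Cl`: in a functional assay on AN3-CA cells (Homo sapiens) for antiproliferative activity, read by MTT assay, with a stated time of 72 h (on this read-out lower numbers stand for stronger inhibition and higher numbers for weaker inhibition), compound 1 gives > 100000 nM, which is a limit of the assay.
Compound 2, `O=C(Nc1ccc(Cl)c(-c2nnc3c(Cl)cccn23)c1)c1ccc(Cl)cc1`: in this assay compound 2 gives > 100000 nM, again a limit of the assay.

Compound 2 therefore stands only at a limit in this assay, with no number of its own. For the measured compounds named here, the single measured step, a step that the two limits leave unreadable from compound 1 to compound 2, cannot be read because the limit of > 100000 nM in this assay, at which 2 of the 2 values shown sit, holds at both of its ends. Compound 3, `O=C(Nc1ccc(Cl)c(-c2nnc3c(Cl)cccn23)c1)c1ccc(Cl)cc1Cl`, differs from compound 2 by chloro in place of hydrogen on an aromatic carbon. Going by the values given here, no measured step bears on this change with a readable size, so nothing in the data points to movement in either direction, and the most likely outcome is another limit. Compound 3 is thus expected to give 150000 nM, within a range from 40000 nM to 600000 nM. That expectation means a step that the limit leaves unreadable from compound 2 to compound 3, estimated as no change beyond the scatter.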

Compound 3, half-maximal inhibitory concentration: 84800 nM
Beside the measured number, compound 3's estimate is 1.8-fold (0.25 log units) above it; measured number inside the range.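

In this assay, for the compounds shown here, compound 3 gives 84800 nM, a number of its own rather than a limit, so this 2,4-dichlorophenyl amide is the first of the series that can be placed on the scale. Chloro in place of hydrogen on the aromatic carbon ortho to a large group gives an at least 1.1-fold lower number from compound 2 to compound 3 (0.07 log units; that floor lies within the scatter), and chloro in place of fluoro gives an at least 1.1-fold lower number from compound 1 to compound 3 (0.07 log units; that floor lies within the scatter). Neither step shows a change beyond the scatter, because each is only a floor with a limit at one end: the limit of > 100000 nM in this assay, at which 2 of the 3 values shown sit.

From the compounds shown here alone, the true size of both steps stays open, and the step between compound 1 and compound 2 cannot be read. The compounds shown also do not tell how an amine or a methoxy group on that same aromatic carbon would compare with chloro.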